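Replacing a benzyl amine with an aryl amine on the shared core

The source may hold more compounds than are shown below. What is called first, only, known or untested is meant among the compounds shown, and "the series" means these compounds.

Of the compounds shown here, two sharing the same core have been tested in a functional assay on MCF7 cells (Homo sapiens) for inhibition, read by CCK-8 assay, with a stated time of 48 h; a higher number here means a weaker inhibitor of growth, a lower number a stronger inhibitor of growth. Compound 1 `Cc1ccccc1Nc1nc(NCc2ccncc2)ncc1Cl` does not yield a number: in this assay compound 1 gives > 100000 nM, which is a limit of the assay, as recorded in the limit of > 100000 nM in this assay, at which 1 of the 2 values shown sits. For the measured compounds named here, compound 2 `CN1CCN(c2ccc(Nc3ncc(Cl)c(NCc4ccc(C(F)(F)F)cc4)n3)nc2)CC1` is the only compound with a numerical result: in this assay compound 2 gives 28400 nM, so it stands as the single measured point. Compound 3 `Cc1ccc(Nc2nc(Nc3ccc(N4CCN(C)CC4)cn3)ncc2Cl)cc1` has not yet been measured. It differs from compound 2 in one place: 4-methylphenyl in place of 4-(trifluoromethyl)benzyl on a nitrogen on an aromatic ring. Going by the values given here, no step between two measured compounds is available, so the size of the change has to be estimated from the structures alone. A modest gain in growth inhibition is expected, with the step of a 2.8-fold lower number from compound 2 to compound 3 (0.45 log units; beyond the scatter) judged to lie beyond the usual scatter but not by a wide margin. Compound 3 is therefore expected to give about 10000 nM in this assay, somewhere between 2000 nM and 50000 nM.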

Compound 3, concentration for 50% growth inhibition: 11400 nM
The estimate for compound 3 lay 1.1-fold (0.06 log units) below the measured number; the measured number falls inside the stated range.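

For the compounds shown here, the exchange of 4-(trifluoromethyl)benzyl for 4-methylphenyl on this nitrogen gives the first measured step at this place in this assay: it shows a 2.5-fold lower number from compound 2 to compound 3 (0.40 log units; beyond the scatter) and so indicates that the number responds to the group carried here, though only modestly. The exchange alters the ring substituent and the link to the nitrogen together, and this single step cannot be divided between those two differences. Nothing measured here gives a reason for the step.

Going by these compounds, it remains open how a 4-methylbenzyl group or a 4-(trifluoromethyl)phenyl group on this nitrogen would compare, which would separate the two differences, and whether an amine or a carboxylic acid on the same ring would shift the number further. Going by these compounds alone, compound 1 differs from the others in more than one place and gives only a limit of the assay, so it adds no step at this position: the limit of > 100000 nM in this assay, at which 1 of the 3 values shown sits.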